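Homologation on two different chains across the series

The source may hold more compounds than are shown below. What is called first, only, known or untested is meant among the compounds shown, and "the series" means these compounds.

Measured so far in a functional assay on the whole organism (Abdomen, strain Swiss) for inhibition, with Mus musculus as the target, with stated times of 30 min, 10 min and 5 min, at a dose of 10 mg/kg by the oral route; a lower number here means a weaker effect, a higher number a stronger effect of the compound at the dose given: compound 1, `CC(=O)c1c(C)nn(CCCN2CCN(c3ccc(C)cc3)CC2)c(=O)c1N`, gives 19%; compound 2, `CCC(=O)c1c(C)nn(CCCN2CCN(c3ccc(C)cc3)CC2)c(=O)c1N`, gives 9%; compound 3, `C=Cc1c(CCC)nn(CCCN2CCN(c3ccc(C)cc3)CC2)c(=O)c1N`, gives 3%.

Compound 2 differs from compound 1 by methyl in place of hydrogen on a saturated chain carbon bound to a carbonyl carbon. That change produced a number 10 percentage points lower from compound 1 to compound 2 (within the scatter). Compound 3 carries a different core from compound 1; the difference between the two cores is not broken down here. Compound 3 stands lowest of the three, within the scatter of compound 2 and beyond it only against compound 1.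

Compound 4, `C=Cc1c(CCCC)nn(CCCN2CCN(c3ccc(C)cc3)CC2)c(=O)c1N`, remains to be measured. It differs from compound 3 by methyl in place of hydrogen on a saturated chain carbon, three bonds along the chain from an aromatic carbon. Going by the values given here, this is the same kind of change as the one from compound 1 to compound 2, not the same: there the place was on a saturated chain carbon bound to a carbonyl carbon, here it is on a saturated chain carbon, three bonds along the chain from an aromatic carbon. Because compound 3 already gives 3%, and because the earlier homologation gave a number 10 percentage points lower from compound 1 to compound 2 (within the scatter), the expected step is a number 1 percentage points higher from compound 3 to compound 4 (within the scatter), no larger than the earlier one. Compound 4 is thus estimated at 4%.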

Compound 4, a percentage reported as inhibition, in the whole organism at one dose (the size of the read-out at that dose, not a potency): 0%
For compound 4 the middle estimate is 4 percentage points above the measured one; measured number inside the range.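

In this assay, methyl in place of hydrogen on a saturated chain carbon, three bonds along the chain from an aromatic carbon, gave a number 3 percentage points lower from compound 3 to compound 4 (within the scatter). Set beside the homologation on the core of compound 1, this step shows no difference between the two cores: the same change on two cores in this assay, a number 10 percentage points lower (within the scatter) from compound 1 to compound 2 and a number 3 percentage points lower (within the scatter) from compound 3 to compound 4, 7 percentage points apart, within the scatter of two such steps

Both steps lie within the scatter, and the added methyl sits at a different place in each pair, so these two pairs do not show that the change has a real effect that carries from one core to the other.

Still open, from the compounds shown here alone, is how a longer chain, a branched chain, an amine or a carboxylic acid in place of the butyl chain would read in this assay.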